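Hydrazone aryl swap: from 4-hydroxyphenyl to 2,4-dichlorophenyl

This account rests on a few compounds, and the source may have more. Where it says the series, first, only, none or still open, it means among the compounds named here.

Among the measured compounds shown here, in a functional assay on SK-MEL-28 cells (Homo sapiens) for inhibition, read by sulforhodamine B assay, with a stated time of 48 h (on this read-out lower numbers stand for stronger inhibition of growth and higher numbers for weaker inhibition of growth), compound 2 `O=C(Cc1csc2nc(-c3ccc(Br)cc3)cn12)N/N=C/c1ccc(O)cc1` gives 100000 nM, the highest number so far, while compound 1 `O=C(Cc1csc2nc(-c3ccc(Br)cc3)cn12)N/N=C/c1ccccc1O` gives 24000 nM. Compound 3 `O=C(Cc1csc2nc(-c3ccc(Br)cc3)cn12)N/N=C/c1ccc(Cl)cc1Cl` has 2,4-dichlorophenyl in place of 4-hydroxyphenyl on a carbon with a double bond to nitrogen. For the measured compounds named here, the only measured step at this place is a 4.2-fold higher number from compound 1 to compound 2 (0.62 log units; beyond the scatter), modest but beyond the scatter. Going by the values given here, it involves only a change between hydroxyphenyl groups, and no measured compound carries chlorine, so it offers a guide to size and only weak evidence on direction. The direction rests on compound 2 holding the higher number of the pair at 100000 nM. The expected change in this assay is a 2.9-fold lower number from compound 2 to compound 3 (0.46 log units; beyond the scatter), similar in size to the measured step. Compound 3 is estimated at 35000 nM, with an expected range of 12000 nM to 100000 nM.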

Compound 3, concentration for total growth inhibition: > 100000 nM
Compound 3: a limit, no number; the forecaster's own chance of this, stated with the estimate: 20%; at least 2.8-fold (0.45 log units) between middle value and limit.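

In this assay compound 3 gives > 100000 nM as a limit and not a number. The change from 4-hydroxyphenyl to 2,4-dichlorophenyl reads only as a number no lower from compound 2 to compound 3 (the limit leaves the size open), so it cannot be read in size. Against 2-hydroxyphenyl the change can be read as an at least 4.1-fold higher number from compound 1 to compound 3 (0.61 log units; beyond the scatter) and, with the step to 4-hydroxyphenyl also beyond the scatter, compound 1 holds the lowest number of the three. At this place on the carbon with a double bond to nitrogen, 2,4-dichlorophenyl therefore adds only a bound to the series: the limit of > 100000 nM in this assay, at which 1 of the 3 values shown sits.

As far as these compounds go, whether a 2-methoxyphenyl or 2-chlorophenyl group would hold the number of compound 1 stays open, so the lower number cannot yet be tied to the hydroxyl group itself. From the compounds shown here alone, the order of compound 2 and compound 3 beyond the limit also stays open, as does the outcome of an amine on this ring.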